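Fluoro to hydrogen on compound 3: working notes

The compounds below may be only part of what the source reports. "The series", "measured", "known", "first", "only" and "open" are said of these compounds alone.

Values measured in a toxicity assay on L02 cells (Homo sapiens) for cytotoxicity, read by MTT assay, with a stated time of 72 h (on this read-out lower numbers stand for stronger inhibition and higher numbers for weaker inhibition), are as follows
- compound 1 `C=CC(=O)N1CCC(Oc2nc(Nc3ccc(N4CCN(C)CC4)c(F)c3)nc3[nH]ccc23)CC1` gives 1890 nM
- compound 2 `C=CC(=O)N1CCC(Oc2nc(Nc3ccc(N4CCN(C)CC4)cc3OC)nc3ccsc23)CC1` gives 1970 nM
- compound 3 `C=CC(=O)N1CCC(Oc2nc(Nc3ccc(N4CCN(C)CC4)c(F)c3)nc3ccsc23)CC1` gives 1400 nM

Compound 3 at 1400 nM stands within the scatter of both compound 1 and compound 2, so the three values form one narrow group and no order among them can be read.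

Compound 4 `C=CC(=O)N1CCC(Oc2nc(Nc3ccc(N4CCN(C)CC4)cc3)nc3ccsc23)CC1` is still unmeasured in this assay and has hydrogen in place of fluoro on an aromatic carbon, ortho to a 4-methylpiperazin-1-yl group and meta to a large group (hydrogen in place of fluoro on an aromatic carbon).

For the measured compounds named here, no measured pair differs in one place only, so this step has no direct precedent. The expectation rests on the spread of the values alone: compound 1 (1890 nM) and compound 2 (1970 nM) stay within the scatter of compound 3 (1400 nM) even though their structures are not the same. A step beyond the scatter in either direction is not expected in this assay from this one replacement. The estimate is a step of a 1.2-fold higher number from compound 3 to compound 4 (0.08 log units; within the scatter) and it is expected to stay within the scatter. For compound 4 the expected value is 1700 nM with an estimated range of 800 nM to 3600 nM and the measurement is still to come.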

Compound 4, half-maximal inhibitory concentration: 8450 nM
Compound 4: the middle estimate sits 5.0-fold (0.70 log units) below what was measured, outside the stated range (above it).
By their numbers in this assay, from the lowest: compounds 3, 1 and 2 (each within the scatter of the next); then compound 4.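

In this assay the replacement of fluoro by hydrogen on an aromatic carbon, ortho to a 4-methylpiperazin-1-yl group and meta to a large group, gives a 6.0-fold higher number from compound 3 to compound 4 (0.78 log units; beyond the scatter) and so shows that this single atom is enough to carry a change beyond the scatter, which the narrow group of earlier values could not show. Hydrogen in place of methoxy on an aromatic carbon gives a 4.3-fold higher number from compound 2 to compound 4 (0.63 log units; beyond the scatter) in the same direction, so among these compounds both the fluoro and the methoxy compound stand at lower numbers than compound 4, and none of the compounds that can be compared in this way goes against that. Nothing measured in this set bears on the reason for either step.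

Still open, going by these compounds, is whether chloro or methyl on the same aromatic carbon would stand with fluoro or with hydrogen in this read-out. Also open, on these data alone, is whether hydrogen in place of fluoro on the core of compound 1 would give a step of similar size, or whether the size of the step belongs to the core of compound 3 alone.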